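The source may report more compounds than this note shows. Statements on the series, on what has been measured and on what is new or still open speak of the compounds shown alone.

Measured compounds:
compound 1 `COc1ccc(C(=O)OC2(C(=O)Nc3ccc([N+](=O)[O-])cc3)CCCCC2)cc1` — 41.2 nM
compound 2 `O=C(OC1(C(=O)Nc2ccc([N+](=O)[O-])cc2)CCCCC1)c1ccccc1I` — 619 nM
compound 3 `O=C(OC1(C(=O)Nc2ccc([N+](=O)[O-])cc2)CCCCC1)c1ccc([N+](=O)[O-])cc1` — 8.7 nM

In a functional assay on MCF7 cells (Homo sapiens) for inhibition, read by MTT assay, with a stated time of 72 h (a lower number here means a stronger inhibitor, a higher number a weaker inhibitor), compound 1 stands second highest of the three numbers; its nearest neighbour is compound 3, with a 4.7-fold lower number from compound 1 to compound 3 (0.68 log units; beyond the scatter), and the furthest is compound 2, with a 15-fold higher number from compound 1 to compound 2 (1.18 log units; beyond the scatter). The remaining pair shows a 71-fold lower number from compound 2 to compound 3 (1.85 log units; beyond the scatter).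

Compound 4 `O=C(OC1(C(=O)Nc2ccc([N+](=O)[O-])cc2)CCCCC1)c1ccccc1` is not yet measured. It differs from compound 1 by hydrogen in place of methoxy on an aromatic carbon. Among the compounds with values here, no measured step removes a group outright; the two that bear on it both alter the same benzoate ring. Swapping one group for another at the same position gave the modest 4.7-fold lower number from compound 1 to compound 3 (0.68 log units; beyond the scatter), while changing both group and position gave the large 15-fold higher number from compound 1 to compound 2 (1.18 log units; beyond the scatter). Loss of the methoxy to hydrogen is the smaller of these kinds of change, so a modest step beyond the scatter is expected, most likely toward a higher number, given that compound 3 with its other para group lies lower than compound 1.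

For compound 4 in this assay the expected value is 80 nM (range 25 nM to 250 nM), which corresponds to an expected 1.9-fold higher number from compound 1 to compound 4 (0.29 log units; within the scatter).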

Compound 4, half-maximal inhibitory concentration: 903 nM
For compound 4 the middle estimate is 11-fold (1.05 log units) below the measured one, outside the stated range (above it).
By their numbers in this assay, from the lowest: compound 3; then compound 1; then compounds 2 and 4 (each within the scatter of the next).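

In this assay, the phenyl compound is no neutral reference point for the series: hydrogen in place of methoxy gives a 22-fold higher number from compound 1 to compound 4 (1.34 log units; beyond the scatter), and hydrogen in place of nitro gives a 100-fold higher number from compound 3 to compound 4 (2.02 log units; beyond the scatter), so in these pairs either group, para to a large group, goes with a far lower number than hydrogen. The iodo group of compound 2 does not share this, since hydrogen in its place gives a 1.5-fold higher number from compound 2 to compound 4 (0.16 log units; within the scatter), and the earlier 15-fold higher number from compound 1 to compound 2 (1.18 log units; beyond the scatter) now reads as a step to the level of the phenyl compound rather than a loss below it. Nothing available explains either the size of these steps or the match between compound 2 and compound 4.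

Open, as far as these compounds go, is whether an amine, a carboxylic acid or a methyl group at the same place would also give a number far below that of compound 4. Within the data shown here, also open is how much of the iodo result belongs to the group and how much to where it sits, as no compound in the set carries iodo at the place held by methoxy in compound 1.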